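The compounds below may be only part of what the source reports. "The series", "measured", "known", "first", "only" and "open" are said of these compounds alone.

Measured in a toxicity assay on Vero C1008 cells (Chlorocebus sabaeus) for cytotoxicity, read by CCK-8 assay; a higher number here means that more compound is tolerated, a lower number that less compound is tolerated:

Compound 1 `COc1cccc2[nH]c(C(=O)N[C@@H](CC(C)C)C(=O)N[C@H](C#N)C[C@@H]3CCCNC3=O)cc12`: > 200000 nM
Compound 2 `COc1cccc2[nH]c(C(=O)N[C@@H](CC(C)C)C(=O)N[C@H](C#N)C[C@@H]3CCNC3=O)cc12`: > 200000 nM
Compound 3 `COc1cccc2[nH]c(C(=O)N[C@@H](CC(C)C)C(=O)N[C@@H](C[C@@H]3CCCNC3=O)C(=O)CO)cc12`: > 200000 nM

All three entries are limits, not numbers. Among the compounds with values here, the series so far shows (the limit of > 200000 nM in this assay, at which 3 of the 3 values shown sit). Compound 1 therefore stands only at its limit of > 200000 nM.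

Next for measurement is compound 4 `CCOc1cccc2[nH]c(C(=O)N[C@@H](CC(C)C)C(=O)N[C@H](C#N)C[C@@H]3CCCNC3=O)cc12`. It differs from compound 1 at a single place: methyl in place of hydrogen on a saturated chain carbon bound to an oxygen on an aromatic ring. In words, this is methyl in place of hydrogen on a saturated chain carbon bound to an oxygen on an aromatic ring, which reads as methoxy to ethoxy.

Within the data shown here, two measured steps bear on this only indirectly, as neither involves the methoxy group: a step that the two limits leave unreadable from compound 1 to compound 2 and a step that the two limits leave unreadable from compound 1 to compound 3. Neither has a readable size, so no magnitude can be carried over to the new change. They offer only the observation that all three compounds sit at the same limit.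

No step beyond the usual scatter is expected in this assay, in either direction, and the reading for compound 4 is expected to be a limit again. The estimated step is a number no higher from compound 1 to compound 4 (the limit leaves the size open), which is expected to stay within the scatter. Compound 4 is estimated at 200000 nM, with an expected range of 100000 nM to 400000 nM.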

Compound 4, half-maximal cytotoxic concentration: > 200000 nM
Compound 4 gave a limit, no number (the forecaster's own chance of this, stated with the estimate: 85%); the middle value lies on the limit itself.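

No step can be read from compound 1 to compound 4, as both entries in this assay are limits and not numbers: the limit of > 200000 nM in this assay, at which 4 of the 4 values shown sit.

The compounds shown leave open at what concentration any of compounds 1, 2, 3 and 4 would reach half-maximal cytotoxicity, and whether methoxy to ethoxy makes any difference to it.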